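The source may report more compounds than this note shows. Statements on the series, on what has been measured and on what is new or still open speak of the compounds shown alone.

Measured in a functional assay on Huh-7 cells (Homo sapiens) for cytotoxicity, read by MTT assay, with a stated time of 72 h; a lower number here means that less compound is tolerated, a higher number that more compound is tolerated:
Compound 1 `CCCS(=O)(=O)N1CCC2(CC1)OOC(C)(C)OO2`: > 100 ug/mL
Compound 2 `CCCS(=O)(=O)N1CCC2(CC1)OOC(C)(C(C)C)OO2`: > 100 ug/mL

Compound 2 stands at > 100 ug/mL, which is a limit of the assay and not a number. Compound 1 gives > 100 ug/mL, and this too is only a limit. All that the data show so far is the limit of > 100 ug/mL in this assay, at which 2 of the 2 values shown sit.

Compound 3 `CCCS(=O)(=O)N1CCC2(CC1)OOC(C)(c1ccccc1)OO2` carries phenyl in place of isopropyl on a saturated ring carbon, between two ring oxygen atoms: phenyl in place of isopropyl on a saturated ring carbon. Going by the values given here, the only measured step that bears on this change is a step that the two limits leave unreadable from compound 1 to compound 2, where isopropyl replaces methyl at the same place. That step has no readable size, so it gives no size or direction to carry over. On these data alone, no step beyond the scatter is therefore expected in this assay, although the phenyl group is untested in this set, and compound 3 may well be reported as a limit too. The estimated step is a number no higher from compound 2 to compound 3 (the limit leaves the size open). For compound 3 the expected value is 100 ug/mL, with an estimated range from 40 ug/mL to 200 ug/mL.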

Compound 3, half-maximal cytotoxic concentration: > 100 ug/mL
Compound 3: only a limit was reported; the forecaster's own chance of this, stated with the estimate: 65%; the middle value sits exactly at the limit.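

Compound 3 is also reported only as a limit, so no step can be read among compound 1, compound 2 and compound 3: the limit of > 100 ug/mL in this assay, at which 3 of the 3 values shown sit. The compounds shown leave open how much of each compound the cells would tolerate, and whether methyl, isopropyl or phenyl on that ring carbon makes any difference to it.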